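This account rests on a few compounds, and the source may have more. Where it says the series, first, only, none or still open, it means among the compounds named here.

Working notes on the series in a functional assay on Jurkat cells (Homo sapiens) for inhibition; on this read-out lower numbers stand for stronger inhibition and higher numbers for weaker inhibition. Compound 2 `CC(C)[C@H](NC(=O)COc1cccc2ccccc12)C(=O)N[C@@H](CC(=O)O)C(=O)CSc1nc(-c2ccccc2)no1` gives 102000 nM, the only number shown so far. Compound 1 `CC(C)[C@H](NC(=O)COc1cccc2ccccc12)C(=O)N[C@@H](CC(=O)O)C(=O)CSc1nc(-c2ccccc2)cs1` gives > 200000 nM, which is a limit of the assay (the limit of > 200000 nM in this assay, at which 1 of the 2 values shown sits). Among the compounds with values here, the single measured step, an at least 1.9-fold lower number from compound 1 to compound 2 (0.29 log units; that floor lies within the scatter), does not rise beyond the scatter. Compound 3 `CC(C)[C@H](NC(=O)COc1cccc2ccccc12)C(=O)N[C@@H](CC(=O)O)C(=O)CSc1nc[nH]n1` differs from compound 2 thus: 1H-1,2,4-triazol-3-yl in place of 3-phenyl-1,2,4-oxadiazol-5-yl on a sulfur. Within the data shown here, no measured step covers this change, and the series sits near the weak end of this assay. The expected step is a 1.6-fold higher number from compound 2 to compound 3 (0.20 log units; within the scatter). Compound 3 is therefore estimated at 160000 nM, within 50000 nM to 400000 nM.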

Compound 3, half-maximal inhibitory concentration: > 200000 nM
Compound 3 gave a limit, no number; the forecaster's own chance of this, stated with the estimate: 40%; at least 1.2-fold (0.09 log units) between middle value and limit.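

Swapping 3-phenyl-1,2,4-oxadiazol-5-yl for 1H-1,2,4-triazol-3-yl on the sulfur gives an at least 1.9-fold higher number from compound 2 to compound 3 (0.29 log units; that floor lies within the scatter), so this second change at the position also leaves no step readable beyond the scatter. The new group has no phenyl ring, yet this change brings no gain in this assay. Compound 1 and compound 3 both stand at a limit, so the step between them cannot be read: the limit of > 200000 nM in this assay, at which 2 of the 3 values shown sit.

Open, as far as these compounds go, is what the phenyl ring and the five-membered ring each contribute, as this change alters both at once. Also open, from the compounds shown here alone, is whether an amine or a carboxylic acid on that phenyl ring would move the series clear of the limit.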